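The compounds below may be only part of what the source reports. "The series", "measured", "known", "first", "only" and "open" are said of these compounds alone.

Working notes on the series, read in an ADME assay on HeLa cells (Homo sapiens) for cytotoxicity, read by MTT assay; a higher number here means a weaker inhibitor, a lower number a stronger inhibitor. Compound 1 (`COc1ccc(C[C@H]2COC(=O)[C@@H]2Cc2ccc(OCc3cn(-c4cccc(Cl)c4)nn3)c(OC)c2)cc1OC`) gives 493000 nM, and compound 2 (`COc1ccc(C[C@H]2COC(=O)[C@@H]2Cc2ccc(OCc3cn(-c4ccc(Cl)cc4)nn3)c(OC)c2)cc1OC`) gives 279000 nM. Compound 2 therefore stands within the scatter of compound 1, and these two numbers form a single level rather than a ranking.

Compound 3 (`COc1ccc(C[C@H]2COC(=O)[C@@H]2Cc2ccc(OCC(=O)N3CCOCC3)c(OC)c2)cc1OC`) follows from compound 2 by (morpholin-4-yl)carbonyl in place of 1-(4-chlorophenyl)-1H-1,2,3-triazol-4-yl on a saturated chain carbon bound to an oxygen on an aromatic ring. In words, this is (morpholin-4-yl)carbonyl in place of 1-(4-chlorophenyl)-1H-1,2,3-triazol-4-yl on a saturated chain carbon bound to an oxygen on an aromatic ring.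

Among the compounds with values here, only one measured step exists: a 1.8-fold lower number from compound 1 to compound 2 (0.25 log units; within the scatter), with 4-chlorophenyl in place of 3-chlorophenyl on an aromatic nitrogen. It bears on the new change only loosely, since the group it alters leaves entirely in compound 3. Within the data shown here, no measured compound carries (morpholin-4-yl)carbonyl, so the data give no direct size for this replacement. Among the measured compounds shown here, with that one small step as the only guide, no step beyond the scatter is expected in this assay, and the range is kept wide. The expected change is a 1.4-fold higher number from compound 2 to compound 3 (0.16 log units; within the scatter). For compound 3 the estimated value is 400000 nM, with an expected range from 150000 nM to 1000000 nM.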

Compound 3, half-maximal inhibitory concentration: >= 600000 nM
Compound 3 was reported as a limit; the forecaster's own chance of this, stated with the estimate: 25%; middle value at least 1.5-fold (0.17 log units) away from the limit.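

In this assay compound 3 stands at a limit of the assay, not at a number: the limit of >= 600000 nM in this assay, at which 1 of the 3 values shown sits.

Even so, the replacement gives an at least 2.1-fold higher number from compound 2 to compound 3 (0.33 log units; beyond the scatter), the first step in the series to lie beyond the scatter, whereas the exchange of 3-chlorophenyl for 4-chlorophenyl gave only a 1.8-fold lower number from compound 1 to compound 2 (0.25 log units; within the scatter). The group on the saturated chain carbon bound to an oxygen on an aromatic ring therefore moves this read-out by more than that exchange on the aromatic nitrogen did, at least against compound 2. Against the other chlorophenyl compound the reading is weaker, at an at least 1.2-fold higher number from compound 1 to compound 3 (0.08 log units; that floor lies within the scatter), so compound 3 is not firmly separated from compound 1.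

Going by these compounds, how far compound 3 lies past its limit stays open, as does whether the shift goes with the entering (morpholin-4-yl)carbonyl or with the loss of the 1-(4-chlorophenyl)-1H-1,2,3-triazol-4-yl. A piperidin-1-ylcarbonyl group in the same place, or a triazole carrying an unsubstituted phenyl, would help to separate those two readings.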